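Lengthening the chain on the shared core: propyl to butyl

The compounds below may be only part of what the source reports. "The series", "measured", "known", "first", "only" and "open" are said of these compounds alone.

Compound 1 `Nc1ncn(Cc2ccc(Cl)cc2Cl)c2ncnc1-2` and compound 3 `CCCn1cnc(N)c2ncnc1-2` share the same core, and in an assay on isolated protein (adrenal medulla) for inhibition of Dopamine beta-hydroxylase (Bos taurus) (a lower number here means a stronger inhibitor, a higher number a weaker inhibitor), compound 1 gives 200 ug/mL while compound 3 gives 200 ug/mL, so compound 3 stands level with compound 1 within the scatter. In this assay compound 2 `CCn1cnc(N)c2ncnc1-2` gives > 200 ug/mL, which is a limit of the assay and not a number (the limit of > 200 ug/mL in this assay, at which 1 of the 3 values shown sits). The step of a number no higher from compound 2 to compound 3 (the limit leaves the size open) therefore has no readable size. Compound 4 `CCCCn1cnc(N)c2ncnc1-2` differs from compound 3 by methyl in place of hydrogen on a saturated chain carbon, three bonds along the chain from an aromatic nitrogen. Among the compounds with values here, the only measured step of this kind, a number no higher from compound 2 to compound 3 (the limit leaves the size open), leaves its size open, so no shift beyond the scatter is expected. The estimated step is no change at the digits printed from compound 3 to compound 4 (within the scatter). Compound 4 is expected to give 200 ug/mL, between 80 ug/mL and 500 ug/mL.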

Compound 4, half-maximal inhibitory concentration: 20 ug/mL
Compound 4: the middle estimate sits 10-fold (1.00 log units) above what was measured; measured number outside the range, below it.
By their numbers in this assay, from the lowest: compound 4; then compounds 1 and 3 (each within the scatter of the next).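

Chain length on the shared core now shows a clear effect: going from propyl to butyl gives a 10-fold lower number from compound 3 to compound 4 (1.00 log units; beyond the scatter), a readable step beyond the scatter in this assay, which the earlier compounds did not provide. Going from the ethyl chain to butyl gives an at least 10-fold lower number from compound 2 to compound 4 (1.00 log units; beyond the scatter). Compound 2 gives > 200 ug/mL, which is a limit of the assay and not a number: the limit of > 200 ug/mL in this assay, at which 1 of the 4 values shown sits.

The compounds shown leave open whether a longer chain, such as pentyl or hexyl, would lower the number further. They also leave open whether a chain carrying an amine or a carboxylic acid would keep this gain.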